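The source may report more compounds than this note shows. Statements on the series, on what has been measured and on what is new or still open speak of the compounds shown alone.

Measured so far:
compound 1, `NC(=O)/C=C/c1ccncc1-c1ccc2ccccc2c1` — 10.5 nM
compound 2, `Cn1ccc2cc(-c3cnccc3/C=C/C(=O)O)ccc21` — 26.8 nM
compound 3, `Cn1ncc2cc(-c3cnccc3/C=C/C(=O)N3CCOCC3)ccc21` — 356 nM

Of the compounds shown here, three have been tested in an assay on a protein complex for inhibition of CDK8/Cyclin C (Homo sapiens), with a stated time of 1 h; a lower number here means a stronger inhibitor, a higher number a weaker inhibitor. Compound 1 gives the lowest number of the three. Compound 2 stands nearest to it, and the gap between the two lies beyond the usual scatter of the measurement. Compound 3 stands furthest away, with a gap that is also well beyond the scatter. Among the compounds with values here, compound 2 and compound 3 differ from compound 1 in more than one place, so no single step between measured compounds can be traced here; their values can only be read side by side.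

The next compound, compound 4, `O=C(/C=C/c1ccncc1-c1ccc2ccccc2c1)NC1CC1`, keeps the core of compound 1 and changes only the carbamoyl group: cyclopropyl in place of hydrogen on an amide-type nitrogen. The change is small in size and adds no hydrogen-bond donor or acceptor. Within the data shown here, with no measured step of the same kind available, the expectation rests on the closeness of compound 4 to compound 1. A modest rise in the number is expected, giving an estimated step of a 2.4-fold higher number from compound 1 to compound 4 (0.38 log units; beyond the scatter), and the estimate may lie within the scatter. For compound 4 the expected value in this assay is 25 nM, with a range from 8 nM to 80 nM.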

Compound 4, half-maximal inhibitory concentration: 40.1 nM
Compound 4: the middle estimate sits 1.6-fold (0.21 log units) below what was measured; measured number inside the range.
By their numbers in this assay, from the lowest: compound 1; then compounds 2 and 4 (each within the scatter of the next); then compound 3.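

Within the data shown here, this is the first change in this assay that can be traced to a single place: with the core of compound 1 kept, cyclopropyl in place of hydrogen on an amide-type nitrogen gives a 3.8-fold higher number from compound 1 to compound 4 (0.58 log units; beyond the scatter) and so lies beyond the scatter. The amide hydrogen can therefore be replaced at a modest cost rather than a complete loss of inhibition, as compound 4 still gives 40.1 nM in this assay on this nitrogen. No measurement shown here bears on why the number rises.

From the compounds shown here alone, a single step cannot tell whether the three-membered ring itself matters or only the added carbon atoms, so it remains open how a methyl group, a longer chain such as n-propyl, or a chain ending in an amine would compare on the same nitrogen. Also open, going by these compounds, is whether cyclopropyl on this nitrogen would give a step of similar size on the other cores, such as those of compound 2 and compound 3, whose comparison with compound 4 cannot be read as one change.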